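The compounds below may be only part of what the source reports. "The series", "measured", "known", "first", "only" and "open" are said of these compounds alone.

Series notes, measured in a functional assay on PC-3 cells (Homo sapiens) for inhibition, read by sulforhodamine B assay; a higher number here means a weaker inhibitor of growth, a lower number a stronger inhibitor of growth:

- compound 1 `FC(F)(F)c1ccc(-c2ccc(-c3ccc(-c4nc5ccccc5[nH]4)cc3)cc2)cc1`: 45200 nM
- compound 2 `CN(C)c1ccc(-c2ccc(-c3ccc(-c4nc5ccccc5[nH]4)cc3)cc2)cc1`: 100000 nM
- compound 3 `Clc1cccc(-c2ccc(-c3ccc(-c4nc5ccccc5[nH]4)cc3)cc2)c1`: 33700 nM

Compound 2 has the highest number of the three at 100000 nM. The measured steps are a 2.2-fold higher number from compound 1 to compound 2 (0.34 log units; beyond the scatter), a 3.0-fold lower number from compound 2 to compound 3 (0.47 log units; beyond the scatter) and a 1.3-fold lower number from compound 1 to compound 3 (0.13 log units; within the scatter).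

Compound 4 `CN(C)c1ccc(-c2ccc(-c3ccc(-c4nc5c(O)cccc5[nH]4)cc3)cc2)cc1` follows from compound 2 by one change: hydroxy in place of hydrogen on an aromatic carbon. All three measured steps swap the substituted phenyl group, and none alters the 1H-benzimidazol-2-yl group, so they offer only a scale. A modest step towards a lower number in this assay is expected, with no direct evidence for its direction. The expected step is a 2.2-fold lower number from compound 2 to compound 4 (0.35 log units; beyond the scatter). Compound 4 is estimated at 45000 nM, with an expected range of 12000 nM to 100000 nM.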

Compound 4, concentration for 50% growth inhibition: 8420 nM
Compound 4: middle estimate off by 5.3-fold (0.73 log units), on the high side; measured number outside the range, below it.
By their numbers in this assay, from the lowest: compound 4; then compounds 3 and 1 (each within the scatter of the next); then compound 2.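

Hydroxy in place of hydrogen, turning 1H-benzimidazol-2-yl into 4-hydroxy-1H-benzimidazol-2-yl, gives a 12-fold lower number from compound 2 to compound 4 (1.07 log units; beyond the scatter) in this assay. This is the first change shown at this end of the molecule, and it is the largest step printed so far, so this position can move growth inhibition further than the phenyl swaps did. Nothing available explains the size of this step.

On these data alone, whether the gain is specific to hydroxy stays open, and a methoxy group or an amine at this position would test that. Also open, as far as these compounds go, is whether it carries over to the trifluoromethyl and 3-chlorophenyl compounds, compound 1 and compound 3.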